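The source may hold more compounds than are shown below. What is called first, only, known or untested is meant among the compounds shown, and "the series" means these compounds.

Measured compounds:
- compound 1, `C[C@@H](NC(=O)Nc1ccccc1F)c1ccccc1`: 97% in an ADME assay on the whole organism with Oryza sativa as the target, tested at 0.1 uM; on this read-out lower numbers stand for a stronger effect and higher numbers for a weaker effect at the one concentration tested
- compound 2, `C[C@H](NC(=O)Nc1ccccc1F)c1ccccc1`: 98%
- compound 3, `C[C@H](NC(=O)Nc1ccccc1I)c1ccccc1`: 99%

On the numbers shown, compound 2 stands second highest of the three, but its steps to both neighbours lie within the scatter: a number 1 percentage points higher from compound 1 to compound 2 (within the scatter), and a number 1 percentage points higher from compound 2 to compound 3 (within the scatter). The first of these is a pure change of configuration as drawn, (the fact that compounds 1 and 2 differ only in the configuration as drawn), and the second exchanges iodo for fluoro on an aromatic carbon; neither moved the read-out beyond the scatter.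

Compound 4, `C[C@H](NC(=O)Nc1cccc(C(F)(F)F)c1F)c1ccccc1`, differs from compound 2 by trifluoromethyl in place of hydrogen on an aromatic carbon. Among the compounds with values here, no measured step introduces a trifluoromethyl group, so the two steps above bear on it only as evidence that changes at this part of the series have so far stayed within the scatter. The expected step is therefore a number 2 percentage points lower from compound 2 to compound 4 (within the scatter), a change not beyond the scatter, with the range widened to allow for an untested group.

Compound 4 is estimated to give 96% in this assay, expected to lie between 85% and 100%.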

Compound 4, a percentage reported as activity, at one concentration (the size of the read-out at that concentration, not a potency): 99%
Compound 4: the middle estimate sits 3 percentage points below what was measured; the measured number falls inside the stated range.
By their numbers in this assay, from the lowest: compounds 1, 2, 3 and 4 (each within the scatter of the next).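

In this assay trifluoromethyl in place of hydrogen on an aromatic carbon, ortho to a fluoro group and meta to a large group, gives a number 1 percentage points higher from compound 2 to compound 4 (within the scatter) on the core of compound 2. The earlier steps shown here changed only a configuration or exchanged fluoro for iodo, whereas this one adds a group of 4 heavy atoms at a carbon that bears hydrogen in compound 2, and the read-out still does not move beyond the scatter. Nothing at hand bears on the reason for this result.

On these data alone, whether any change on this aromatic ring can move the read-out beyond the scatter remains open. As far as these compounds go, an amine or a carboxylic acid in place of trifluoromethyl at this carbon would test this with a different kind of group, and the same group on the other configuration also remains open.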